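This account rests on a few compounds, and the source may have more. Where it says the series, first, only, none or still open, it means among the compounds named here.

Working notes on the series. Of the compounds shown here, three sharing one core have been measured in a functional assay (muscle tissue) with Cavia porcellus as the target; on this read-out higher numbers stand for an effect only at larger amounts of compound and lower numbers for an effect already at smaller amounts. Compound 1 `COC(=O)C1=C(C)N=C(C)/C(=C(\O)OC)C1c1cccc(OC(C)=O)c1` gives 6030 nM; compound 2 `COC(=O)C1=C(C)N=C(C)/C(=C(\O)OC)C1c1cccc([N+](C)(C)C)c1` gives 50100 nM; compound 3 `COC(=O)C1=C(C)N=C(C)/C(=C(\O)OC)C1c1cccc(N)c1` gives 2000 nM. Compound 3 holds the lowest number of the three: the change from compound 1 gave a 3.0-fold lower number from compound 1 to compound 3 (0.48 log units; beyond the scatter), and the change from compound 2 gave a 25-fold lower number from compound 2 to compound 3 (1.40 log units; beyond the scatter). Between compound 1 and compound 2 the change gave an 8.3-fold higher number from compound 1 to compound 2 (0.92 log units; beyond the scatter). All three measured steps alter the group on the aromatic carbon of the phenyl ring while the core is kept.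

Compound 4 `COC(=O)C1=C(C)N=C(C)/C(=C(\O)OC)C1c1ccccc1F` is not yet measured. It differs from compound 3 by 2-fluorophenyl in place of 3-aminophenyl on a saturated ring carbon. The measured steps bear on it only in showing that the group on the phenyl ring moves the number in this assay by modest to large amounts, from a 3.0-fold lower number from compound 1 to compound 3 (0.48 log units; beyond the scatter) up to a 25-fold lower number from compound 2 to compound 3 (1.40 log units; beyond the scatter); none of them introduces fluorine, and none removes a hydrogen-bond donor and acceptor at once. The direction of the change is therefore open. For compound 4 the expected step is a 1.3-fold higher number from compound 3 to compound 4 (0.10 log units; within the scatter), wide in its uncertainty. Compound 4 is estimated at 2500 nM, within a range from 500 nM to 12000 nM.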

Compound 4, half-maximal effective concentration: 42.7 nM
Compound 4: the middle estimate sits 59-fold (1.77 log units) above what was measured; measured number below the stated range.
By their numbers in this assay, from the lowest: compound 4; then compound 3; then compound 1; then compound 2.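

In this assay, a 47-fold lower number from compound 3 to compound 4 (1.67 log units; beyond the scatter) shows that a low number on this core does not depend on the hydrogen-bond donor and acceptor counted on 3-aminophenyl, since 2-fluorophenyl carries neither and the number still falls well beyond the scatter. Unlike the earlier steps, which exchanged the group while keeping its place on the phenyl ring, this change replaces the amino group with fluorine and also moves the substituent, as the names 3-aminophenyl and 2-fluorophenyl show, so this position on the saturated ring carbon tolerates more than the earlier compounds revealed. Nothing at hand gives a measured reason for the size of this step.

The compounds shown leave open whether the step follows the loss of the amino group, the arrival of fluorine or the new place on the phenyl ring; fluorine where 3-aminophenyl holds its amino group, or an amino group where 2-fluorophenyl holds its fluorine, would separate these. Also open, on these data alone, is what a plain phenyl group would give, or a chlorine or nitro group in place of that fluorine.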